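Aryl change on sulfur: compound 3 to compound 4

The source may hold more compounds than are shown below. What is called first, only, known or untested is meant among the compounds shown, and "the series" means these compounds.

- compound 1 `CC(O)(CSc1cccc(S(F)(F)(F)(F)F)c1)C(=O)Nc1ccc([N+](=O)[O-])c(C(F)(F)F)c1` gives 8800 nM
- compound 2 `CC(O)(CSc1ccc(S(F)(F)(F)(F)F)cc1)C(=O)Nc1cccc(S(F)(F)(F)(F)F)c1` gives 13100 nM
- compound 3 `CC(O)(CSc1ccc(F)cc1)C(=O)Nc1cccc(S(F)(F)(F)(F)F)c1` gives 30200 nM

In a functional assay on CWR22R cells (Homo sapiens) for antiproliferative activity, read by propidium iodide staining, with a stated time of 96 h (a lower number here means a stronger inhibitor, a higher number a weaker inhibitor), compound 3 gives 30200 nM as the highest of the three numbers, and it lies beyond the scatter from both other compounds. The change to compound 4 `CC(O)(CSc1ccccc1C(F)(F)F)C(=O)Nc1cccc(S(F)(F)(F)(F)F)c1` is 2-(trifluoromethyl)phenyl in place of 4-fluorophenyl on a sulfur and, in words, puts 2-(trifluoromethyl)phenyl in place of 4-fluorophenyl on a sulfur.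

Among the measured compounds shown here, one measured step bears on this: a 2.3-fold higher number from compound 2 to compound 3 (0.36 log units; beyond the scatter) is modest and also concerns the substituent on the aromatic group held by the sulfur. For the measured compounds named here, no measured compound carries trifluoromethyl on that group. Compound 1 differs from compound 3 in more than one place, so its value offers no direct guide.

Going by the values given here, with a 2.3-fold higher number from compound 2 to compound 3 (0.36 log units; beyond the scatter) as the only evidence, a small shift toward a lower number is expected in this assay and may not clear the scatter. The estimated step is a 1.5-fold lower number from compound 3 to compound 4 (0.18 log units; within the scatter) and carries wide uncertainty. For compound 4 the expected value is 20000 nM with an estimated range of 8000 nM to 50000 nM in this single-step reading.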

Compound 4, half-maximal inhibitory concentration: 13200 nM
Beside the measured number, compound 4's estimate is 1.5-fold (0.18 log units) above it; low and high end bracket the measured number.
By their numbers in this assay, from the lowest: compounds 1, 2 and 4 (each within the scatter of the next); then compound 3.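

In this assay the aryl group on the sulfur proves open to a substituent of a different kind and place: 2-(trifluoromethyl)phenyl in place of 4-fluorophenyl gives a 2.3-fold lower number from compound 3 to compound 4 (0.36 log units; beyond the scatter) and so counts as a real change rather than scatter. Among the compounds shown here, until now the only reading at this sulfur was a 2.3-fold higher number from compound 2 to compound 3 (0.36 log units; beyond the scatter), which left open whether the group of five fluorines on sulfur was the one substituent that could hold the lower number; the new result shows it is not the only one, since compound 2 at 13100 nM and compound 4 at 13200 nM lie within the scatter of each other. Nothing measured in this series accounts for the difference between these aryl groups.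

Whether the step belongs to the trifluoromethyl group itself or to where it sits on the ring stays open, as the compounds shown offer no pair that separates the two. Also open, as far as these compounds go, is how a plain phenyl, or a phenyl carrying a nitrile or an amine, would read on this sulfur with the rest of the shared core unchanged.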